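Chain change on compound 2

A few compounds are considered here, and "the series" means these few. Any claim that something is new, unique, unknown or untested is made for them only; others in the source may bear on it.

In a functional assay on MDA-MB-231 cells (Homo sapiens) for antiproliferative activity, read by MTT assay (a lower number here means a stronger inhibitor, a higher number a weaker inhibitor), compound 1 (`CC/C=C\C/C=C\C/C=C\CCCCCCCc1cc(=O)c2c(O)c(C)c(O)c(C)c2o1`) gives 6790 nM, compound 3 (`CC/C=C\C/C=C\C/C=C\CCCCCCCc1cc(=O)c2c(O)c(C)c(OCOC)cc2o1`) gives 6790 nM and compound 2 (`CC/C=C\C/C=C\C/C=C\CCCCCCCc1cc(=O)c2c(O)c(C)c(OCOC)c(C)c2o1`) gives 16100 nM, the highest number of the three and so the weakest inhibitor. Compound 4 (`CCCCCCCCCCCCCCCc1cc(=O)c2c(O)c(C)c(OCOC)c(C)c2o1`) departs from compound 2 only in the chain: a group of 8 heavy atoms (8 carbon; no ring) in place of a group of 10 heavy atoms (10 carbon; no ring), on a saturated chain carbon, seven bonds along the chain from an aromatic carbon; the three double bonds outside aromatic rings leave with it. Going by the values given here, no measured step touches the chain. The two available steps, a 2.4-fold higher number from compound 1 to compound 2 (0.37 log units; beyond the scatter) and a 2.4-fold lower number from compound 2 to compound 3 (0.37 log units; beyond the scatter), both lie on the core and are modest, so they suggest a scale but no direction. In this assay, no shift beyond the scatter is expected, and the estimated step is a 1.0-fold lower number from compound 2 to compound 4 (0.00 log units; within the scatter). The estimate for compound 4 is 16000 nM, with an expected range of 6500 nM to 40000 nM.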

Compound 4, half-maximal inhibitory concentration: > 87000 nM
Compound 4 ended at the assay's limit; the forecaster's own chance of this, stated with the estimate: 15%; middle value at least 5.4-fold (0.73 log units) away from the limit.
By their numbers in this assay, from the lowest: compounds 1 and 3 (each within the scatter of the next); then compound 2. At a limit, above all of these: compound 4.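

Going by these compounds alone, the chain counts: in this assay, octyl in place of the unsaturated group, with the three double bonds gone, gives an at least 5.4-fold higher number from compound 2 to compound 4 (0.73 log units; beyond the scatter) on a part of the structure that no core step touched. That step exceeds the core step of a 2.4-fold lower number from compound 2 to compound 3 (0.37 log units; beyond the scatter) in size. Compound 4 stands at a limit and not at a number, and the full size of its step stays unread: the limit of > 87000 nM in this assay, at which 1 of the 4 values shown sits.

Open, as far as these compounds go, is whether the double bonds or the chain length carries the step, as both change together here. A longer saturated chain would help to separate the two.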